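Solubility notes on a quinazoline-like amide series: compound 4

The source may hold more compounds than are shown below. What is called first, only, known or untested is meant among the compounds shown, and "the series" means these compounds.

Measured compounds:
compound 1, `COc1cc2nnc(C(N)=O)c(Nc3ccc(C)cc3F)c2cc1N1CCCN(C)CC1`, 54000 nM
compound 2, `COc1cc2nnc(C(N)=O)c(Nc3ccc(C)cc3F)c2cc1N1CCN(C(C)C)CC1`, 40000 nM
compound 3, `COc1cc2nnc(C(N)=O)c(Nc3ccc(C)cc3F)c2cc1N1CCC(N(C)C)CC1`, 340000 nM

In a physicochemical assay for solubility (on this read-out lower numbers stand for lower solubility and higher numbers for higher solubility), compound 2 sits at the low end of the three numbers. Its nearest neighbour is compound 1, and the step of a 1.4-fold lower number from compound 1 to compound 2 (0.13 log units; within the scatter) does not separate the two. Compound 3 stands apart: the step of an 8.5-fold higher number from compound 2 to compound 3 (0.93 log units; beyond the scatter) and the step of a 6.3-fold higher number from compound 1 to compound 3 (0.80 log units; beyond the scatter) are both beyond the scatter, though still modest.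

Compound 4, `COc1cc2nnc(C(N)=O)c(Nc3ccc(C)cc3F)c2cc1N1CCN(S(C)(=O)=O)CC1`, is not yet measured in this assay. It differs from compound 2 in one place: methylsulfonyl in place of isopropyl on an amine nitrogen in a ring. Going by the values given here, every measured step so far swaps one ring substituent on the aromatic carbon for another ring substituent of the same general kind; none of them exchanges an alkyl group on a ring nitrogen for methylsulfonyl, so no measured step bears directly on this change. The spread of the three measured values sets the scale: the moves seen were at most modest.

Among the compounds with values here, with no direct precedent, compound 4 is expected to move downward from compound 2 by about a 2.7-fold lower number from compound 2 to compound 4 (0.43 log units; beyond the scatter), a step that may or may not clear the scatter. The estimate for compound 4 in this assay is 15000 nM, with a range from 3000 nM to 60000 nM.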

Compound 4, solubility: < 1000 nM
Compound 4 was reported as a limit (the forecaster's own chance of this, stated with the estimate: 5%); middle value at least 15-fold (1.17 log units) from the limit.
By their numbers in this assay, from the lowest: compounds 2 and 1 (each within the scatter of the next); then compound 3. At a limit, below all of these: compound 4.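

In this assay compound 4 is reported as a limit and not a number: the limit of < 1000 nM in this assay, at which 1 of the 4 values shown sits.

Going by these compounds alone, with methylsulfonyl in place of isopropyl on the amine nitrogen in the ring as the only difference, the series shows an at least 40-fold lower number from compound 2 to compound 4 (1.60 log units; beyond the scatter), a large step, whereas no step among compound 1, compound 2 and compound 3 went beyond modest. So the group on this ring nitrogen can move the read-out further than any swap of the whole ring substituent seen among those three compounds, and the wider swaps on the aromatic carbon agree, giving an at least 54-fold lower number from compound 1 to compound 4 (1.73 log units; beyond the scatter) and an at least 340-fold lower number from compound 3 to compound 4 (2.53 log units; beyond the scatter).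

From the compounds shown here alone, how far the true value of compound 4 lies past its limit remains open, so each of these steps is known only as a minimum. Also open, going by these compounds, is whether the drop belongs to methylsulfonyl specifically or would follow other non-alkyl groups on the same nitrogen, such as acetyl or methoxycarbonyl, and a hydrogen on that nitrogen would give a further point of comparison.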